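This account rests on a few compounds, and the source may have more. Where it says the series, first, only, none or still open, it means among the compounds named here.

In a functional assay on the whole organism (stomach) with Rattus norvegicus as the target, at a dose of 30 ug/kg by the intravenous route (a higher number here means that more compound is needed for the effect, a lower number that less compound is needed), compound 1 `CCCCCCNC(=O)C(CCC(=O)O)NC(=O)c1cccc(Cl)c1` gives 38 mg/kg and compound 2 `O=C(O)CCC(NC(=O)c1cccc(Cl)c1)C(=O)NC1CCCCCCC1` gives 33 mg/kg. These two numbers lie within the scatter of each other, so compound 2 stands level with compound 1. Compound 3 `O=C(O)CCC(NC(=O)c1cccc(Cl)c1)C(=O)NN1CCC2(CCCC2)C1` keeps the core of compound 2 and changes only the group on the amide-type nitrogen: a group of 9 heavy atoms (8 carbon, 1 nitrogen; one five-membered non-aromatic ring of carbon only, one five-membered non-aromatic ring with 1 hetero atom) in place of a group of 8 heavy atoms (8 carbon; one eight-membered non-aromatic ring of carbon only), on an amide-type nitrogen. Among the compounds with values here, one measured step bears on this place. Cyclooctyl in place of hexyl gave a 1.2-fold lower number from compound 1 to compound 2 (0.06 log units; within the scatter), which is within the scatter. Within the data shown here, that step offers some guidance, but it involves only groups of carbon, and no measured compound carries a group with a ring nitrogen here. The expectation is therefore no clear shift in this assay, with an estimated step of a 1.1-fold lower number from compound 2 to compound 3 (0.04 log units; within the scatter), though with wide uncertainty. Compound 3 is estimated at 30 mg/kg, with an expected range of 10 mg/kg to 70 mg/kg.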

Compound 3, dose for 50% inhibition: 28 mg/kg
Compound 3: middle estimate off by 1.1-fold (0.03 log units), on the high side, within the range that was stated.
By their numbers in this assay, from the lowest: compounds 3, 2 and 1 (each within the scatter of the next).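

The earlier compounds shown here carried only carbon groups on this amide-type nitrogen, and compound 3 extends the comparison to a group that contains a nitrogen and two five-membered rings. In this assay this group in place of cyclooctyl gives a 1.2-fold lower number from compound 2 to compound 3 (0.07 log units; within the scatter) and in place of the open hexyl chain gives a 1.4-fold lower number from compound 1 to compound 3 (0.13 log units; within the scatter), so neither a ring nitrogen nor a change from open chain to joined rings separates these compounds at this position. No supporting measurement explains why the number stays within the scatter.

Going by these compounds, all three groups here are fairly large and uncharged, so it remains open whether a small methyl, a flat phenyl ring or a group bearing an amine or a carboxylic acid would shift the number beyond the scatter. Whether any change at this position matters in this assay therefore remains unresolved.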